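The source may hold more compounds than are shown below. What is called first, only, known or untested is meant among the compounds shown, and "the series" means these compounds.

Measured so far:
compound 1 `Nc1scc(CN2CCN(c3ccc(Cl)cc3F)CC2)c1C(=O)c1ccc(Cl)cc1`: -81%
compound 2 `Nc1scc(CN2CCN(c3ccccc3Cl)CC2)c1C(=O)c1ccc(Cl)cc1`: -18%

In a functional assay on CHO cells with adenosine receptor A1 (Homo sapiens) as the target, read by cAMP accumulation and immunoassay, with a stated time of 6 min, tested at 10 uM (on this read-out higher numbers stand for a weaker effect at the one concentration tested and lower numbers for a stronger effect), compound 1 gives -81%, and compound 2 gives -18%. Compound 2 stands highest of the two numbers; the step of a number 63 percentage points higher from compound 1 to compound 2 (beyond the scatter) is large and beyond the scatter, so the group on the amine nitrogen in a ring clearly matters on this read-out.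

Compound 3 `Nc1scc(CN2CCN(c3cc(Cl)ccc3Cl)CC2)c1C(=O)c1ccc(Cl)cc1` differs from compound 2 by chloro in place of hydrogen on an aromatic carbon. Going by the values given here, the only measured step, a number 63 percentage points higher from compound 1 to compound 2 (beyond the scatter), bears on it indirectly: removing chloro and fluoro from that ring raised the number strongly. Among the compounds with values here, putting a chloro back, although at a different place, is therefore expected to lower the number, but with wide uncertainty, since no step tests this exact place.

Compound 3 is estimated at -45%, with a range from -80% to -10%. The expected step is a number 27 percentage points lower from compound 2 to compound 3 (beyond the scatter), downward and likely beyond the scatter.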

Compound 3, a percentage reported as activity, at one concentration (the size of the read-out at that concentration, not a potency): -62%
Estimate against measurement, compound 3: 17 percentage points above; the measured number falls inside the stated range.
By their numbers in this assay, from the lowest: compound 1; then compound 3; then compound 2.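

In this assay, chloro on the aromatic carbon meta to a large group and para to a chloro group gives a number 44 percentage points lower from compound 2 to compound 3 (beyond the scatter), so this place on the 2-chlorophenyl group has a strong bearing on the read-out. The two rings carrying two halogens are not interchangeable: 2,5-dichlorophenyl in place of 4-chloro-2-fluorophenyl gives a number 19 percentage points higher from compound 1 to compound 3 (beyond the scatter), so the kind and placing of the halogens count, not just their number. No measurement at hand bears on the origin of either step.

Open, from the compounds shown here alone, is whether the lower number is particular to chloro at this place, or would also follow with fluoro, methyl or methoxy there. Also open, going by these compounds, is whether the step persists when the chloro already present in compound 2 gives way to a methyl.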